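The compounds below may be only part of what the source reports. "The series", "measured", "known", "first", "only" and "open" are said of these compounds alone.

In a functional assay on MCF7 cells (Homo sapiens) for cytotoxicity, read by colorimetric assay and MTT assay (on this read-out lower numbers stand for stronger inhibition and higher numbers for weaker inhibition), compound 1 (`CCOC(=O)Cn1c(=O)c(-c2ccc(OC)cc2)cc2c(OC)cc(OC)cc21`) gives 10000 nM, compound 2 (`Cn1c(=O)c(-c2ccc(O)cc2)cc2c(O)cc(O)cc21`) gives 10000 nM, and compound 3 (`COc1cc(OC)c2cc(-c3ccc(O)cc3)c(=O)n(C)c2c1`) gives 10000 nM. Compound 3 therefore stands level with the other two compounds. Compound 4 (`COc1cc(OC)c2cc(-c3ccc(OC(C)=O)cc3)c(=O)n(C)c2c1`) differs from compound 3 by a single change: acetyl in place of hydrogen on an oxygen on an aromatic ring, with acetyl in place of hydrogen on an oxygen on an aromatic ring, or hydroxy to acetoxy. For the measured compounds named here, no measured pair here isolates one structural change, so no step can be read directly. The three measured compounds differ in structure yet share one value, so no shift beyond the scatter is expected in this assay. The expected step, no change at the digits printed from compound 3 to compound 4 (within the scatter), should stay within the scatter. The estimated value for compound 4 is 10000 nM, with an expected range from 4000 nM to 20000 nM.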

Compound 4, half-maximal inhibitory concentration: 10000 nM
Estimate against measurement, compound 4: no gap at the digits printed; low and high end bracket the measured number.
By their numbers in this assay, from the lowest: compounds 1, 2, 3 and 4 (each within the scatter of the next).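

In this assay, for the compounds shown here, acetyl in place of hydrogen on an oxygen on an aromatic ring gives no change at the digits printed from compound 3 to compound 4 (within the scatter) as the first step here that isolates a single structural change. Hydroxy to acetoxy at this place therefore leaves the read-out unmoved, and compound 4 shares its value with compounds 1, 2 and 3. Nothing available here explains this result. From the compounds shown here alone, whether an amine or a carboxylic acid at this place would shift the value remains open. With all four values level, the compounds shown identify no change on the core that alters this read-out.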